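The source may hold more compounds than are shown below. What is called first, only, known or untested is meant among the compounds shown, and "the series" means these compounds.

Measured so far:
compound 1 `O=c1c(S(=O)(=O)c2ccc(F)cc2F)cc2cnc(Nc3ccc4[nH]ccc4c3)nc2n1C1CCCC1`: 5000 nM
compound 2 `Cn1c(=O)c(S(=O)(=O)c2ccc(F)cc2F)cc2cnc(Nc3ccncn3)nc21`: 30000 nM
compound 3 `Cn1c(=O)c(S(=O)(=O)c2ccc(Cl)cc2)cc2cnc(Nc3ccc4[nH]ccc4c3)nc21`: 100 nM

In a functional assay on K562 cells (Homo sapiens) for inhibition, read by trypan blue exclusion, with a stated time of 72 h (on this read-out lower numbers stand for stronger inhibition and higher numbers for weaker inhibition), compound 2 gives 30000 nM, the highest number of the three, so it is the weakest inhibitor here. Its nearest neighbour is compound 1, which in this assay gives 5000 nM, a gap beyond the usual scatter; compound 3, which in this assay gives 100 nM, lies furthest away.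

The unmeasured compound 4 `Cn1c(=O)c(S(=O)(=O)c2ccc(F)cc2F)cc2cnc(Nc3ccc4c(c3)C(=O)C(=O)N4)nc21` differs from compound 2 at one place:

a group of 11 heavy atoms (8 carbon, 1 nitrogen, 2 oxygen; one five-membered non-aromatic ring with 1 hetero atom, one six-membered aromatic ring of carbon only) in place of a group of 6 heavy atoms (4 carbon, 2 nitrogen; one six-membered aromatic ring with 2 hetero atoms), on a nitrogen on an aromatic ring

Going by the values given here, compounds 1 and 3 both carry a two-ring group on that nitrogen, and both give lower numbers than compound 2, with no measured compound going against this. Compound 4 also carries a two-ring group there, with a hydrogen-bond donor that the pyrimidin-4-yl of compound 2 lacks. Among the compounds with values here, no directly comparable step has been measured, so the expectation rests on this likeness alone. For compound 4 a drop beyond the scatter is expected, and the step from a 10-fold lower number from compound 2 to compound 4 (1.00 log units; beyond the scatter) is estimated accordingly. Compound 4 is therefore expected to give about 3000 nM, within a range from 500 nM to 20000 nM.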

Compound 4, half-maximal inhibitory concentration: 30000 nM
Compound 4: the middle estimate sits 10-fold (1.00 log units) below what was measured; the measured number lies above the stated range.
By their numbers in this assay, from the lowest: compound 3; then compound 1; then compounds 2 and 4 (each within the scatter of the next).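

In this assay, putting the larger two-ring group with its hydrogen-bond donor in place of pyrimidin-4-yl, on a nitrogen on an aromatic ring, gives no change at the digits printed from compound 2 to compound 4 (within the scatter). Going by these compounds alone, this is the first clean one-place comparison at this position, and it shows that a two-ring group there does not by itself go with a lower number: compound 4 goes against the trend suggested by compounds 1 and 3, which also differ from compound 2 elsewhere in the molecule. Nothing measured here explains why this change leaves the number where it is.

The compounds shown leave open whether the two-ring group of compound 3 would lower the number if it were placed on the core of compound 2, which would show whether the lower number of compound 3 belongs to that group or to another part of the molecule. They also leave open what a plain phenyl, or a phenyl ring carrying an amine such as piperazine, would do on this nitrogen.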